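Chloro at a Second Ring Position on a Hydroxamic Acid

A few compounds are considered here, and "the series" means these few. Any claim that something is new, unique, unknown or untested is made for them only; others in the source may bear on it.

Measured so far:
Compound 1 `CO/N=C1/C(=O)N(CCCCCCC(=O)NO)c2ccccc21` gives 1220 nM in a functional assay on ASPC1 cells (Homo sapiens) for antiproliferative activity, read by sulforhodamine B assay, with a stated time of 48 h; a higher number here means a weaker inhibitor, a lower number a stronger inhibitor.
Compound 2 `CO/N=C1/C(=O)N(CCCCCCC(=O)NO)c2ccc(Cl)cc21` gives 490 nM in this assay.

Both compounds share one core, a ring system carrying a seven-carbon chain that ends in a hydroxamic acid. Compound 1 stands at the highest of the two numbers, so it is the weaker inhibitor of the pair; its nearest neighbour is compound 2, reached through a 2.5-fold lower number from compound 1 to compound 2 (0.40 log units; beyond the scatter), a step beyond the scatter.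

Compound 3 `CO/N=C1/C(=O)N(CCCCCCC(=O)NO)c2c(Cl)cccc21` has not yet been measured. Relative to compound 1 it shows (chloro in place of hydrogen on an aromatic carbon). Going by the values given here, only one measured step bears on this change, a 2.5-fold lower number from compound 1 to compound 2 (0.40 log units; beyond the scatter), where a chloro also replaced hydrogen on an aromatic carbon of the same core, though on another carbon of that ring. Whether a chloro at the carbon chosen in compound 3 acts alike is not known from these two compounds. A lowering of modest size is therefore expected in this assay, toward a stronger inhibitor, with a real chance that the step stays within the scatter.

For compound 3 the estimate is 800 nM, ranging from 350 nM to 1800 nM. Relative to compound 1 this estimate means an expected 1.5-fold lower number from compound 1 to compound 3 (0.18 log units; within the scatter).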

Compound 3, half-maximal inhibitory concentration: 630 nM
Estimate against measurement, compound 3: 1.3-fold (0.10 log units) above; measured number inside the range.
By their numbers in this assay, from the lowest: compounds 2, 3 and 1 (each within the scatter of the next, the first and the last beyond it).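

In this assay, replacing the hydrogen ortho to a fused ring with a chloro gives a 1.9-fold lower number from compound 1 to compound 3 (0.29 log units; within the scatter) and so cannot be told apart from the normal variation between repeated measurements. The same replacement on another carbon of that ring gives a 2.5-fold lower number from compound 1 to compound 2 (0.40 log units; beyond the scatter) and does clear the scatter, so the earlier step alone did not show that a chloro at any carbon of the ring would give a lowering beyond the scatter. Nothing measured here explains how the chloro acts at either carbon.

The compounds shown leave open whether a fluoro or a methoxy group at this same aromatic carbon would give a step beyond the scatter, and whether chloro at the remaining carbons of the ring would behave like either of these two examples. They also leave open whether the effect of a chloro at this carbon would hold with a shorter or longer chain leading to the hydroxamic acid.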